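The source may report more compounds than this note shows. Statements on the series, on what has been measured and on what is new or still open speak of the compounds shown alone.

In a functional assay, read by fluorescence and spectrophotometry, with a stated time of 1 h (a higher number here means that more compound is needed for the effect, a lower number that less compound is needed), compound 1 `CCCCCCCS(=O)(=O)/C=C/c1ccc(O)c(O)c1` gives 7100 nM, compound 2 `O=S(=O)(/C=C/c1ccc(O)c(O)c1)CC1CCCO1` gives 10500 nM, and compound 3 `CCCCCCS(=O)(=O)/C=C/c1ccc(O)c(O)c1` gives 7300 nM. Compound 3 sits among three numbers that all lie within the scatter of one another, nearest to compound 1 and furthest from compound 2. Compound 4 `CCCCCCCCCS(=O)(=O)/C=C/c1ccc(O)c(O)c1` differs from compound 3 by propyl in place of hydrogen on a saturated chain carbon, six bonds along the chain from a sulfonyl sulfur. The step that bears most directly on this change at the same place is a 1.0-fold higher number from compound 1 to compound 3 (0.01 log units; within the scatter); the remaining steps, a 1.5-fold higher number from compound 1 to compound 2 (0.17 log units; within the scatter) and a 1.4-fold lower number from compound 2 to compound 3 (0.16 log units; within the scatter), likewise stayed within the scatter. No step beyond the scatter is therefore expected in this assay. Compound 4 is expected to give 6000 nM, within a range from 2500 nM to 14000 nM. The estimated step is a 1.2-fold lower number from compound 3 to compound 4 (0.09 log units; within the scatter).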

Compound 4, half-maximal effective concentration: 7700 nM
Beside the measured number, compound 4's estimate is 1.3-fold (0.11 log units) below it, and the stated range covers the measured number.
By their numbers in this assay, from the lowest: compounds 1, 3, 4 and 2 (each within the scatter of the next).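

In this assay, propyl in place of hydrogen on a saturated chain carbon, six bonds along the chain from a sulfonyl sulfur, gives a 1.1-fold higher number from compound 3 to compound 4 (0.02 log units; within the scatter), and ethyl in place of hydrogen, seven bonds along the chain, gives a 1.1-fold higher number from compound 1 to compound 4 (0.04 log units; within the scatter). The earlier compounds had shown a step within the scatter at this end of the chain only for methyl in place of hydrogen. Going by these compounds, whether an amine, a carboxylic acid or a longer chain at this place would give a step beyond the scatter stays open. No supporting data explain why these numbers stay so close.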